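A few compounds are considered here, and "the series" means these few. Any claim that something is new, unique, unknown or untested is made for them only; others in the source may bear on it.

Compound 1 `CCc1ccc(N(CC(C)C)S(=O)(=O)c2ccc3cc(OCC4CCOCC4)c(CO)cc3c2)cc1` is a sulfonamide whose core carries a hydroxymethyl group. In a physicochemical assay for lipophilicity, at pH 7.4 (on this read-out higher numbers stand for higher lipophilicity and lower numbers for lower lipophilicity), compound 1 gives 5.1. Going by the values given here, the only other measured compound, compound 2 `CCc1ccc(N(CC(C)C)S(=O)(=O)c2ccc3c(c2)C(=O)CC(C2CCN(C(=O)C4CCCC4)CC2)O3)cc1`, gives 5.13 in this assay. On these two numbers compound 1 sits essentially level with compound 2: the gap between them lies within the scatter of repeated measurements, so the two cannot be told apart.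

The step to compound 3 `CCc1ccc(N(CC(C)C)S(=O)(=O)c2ccc3cc(OCC4CCOCC4)c(C(=O)OCC4CCOCC4)cc3c2)cc1` changes a single place on the core of compound 1: ((oxan-4-yl)methoxy)carbonyl in place of hydroxymethyl on an aromatic carbon. Among the compounds with values here, nothing measured so far shows how this assay responds to such a swap, since no two measured compounds differ in one place. On the change alone, with a hydrogen-bond donor leaving and a larger, carbon-rich fragment entering, an upward step in this assay is expected, estimated at a number 0.90 log units higher from compound 1 to compound 3 (beyond the scatter) and clearly beyond the scatter. Compound 3 is therefore estimated at 6, within a range from 5.3 to 6.7.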

Compound 3, distribution coefficient: 6.34
Compound 3: the middle estimate sits 0.34 log units below what was measured, within the range that was stated.
By their numbers in this assay, from the lowest: compounds 1 and 2 (each within the scatter of the next); then compound 3.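

In this assay, going by these compounds alone, the swap of hydroxymethyl for ((oxan-4-yl)methoxy)carbonyl on this aromatic carbon gives a number 1.24 log units higher from compound 1 to compound 3 (beyond the scatter) and is the first change in one place to be read on this core. This position, ortho to a (oxan-4-yl)methoxy group, is therefore one where the choice of group can move this number by a large step. The swap combines several differences, with a hydrogen-bond donor leaving and a non-aromatic ring and a double bond entering, and no measurement at hand explains the size of the step.

These compounds cannot separate the share of each difference. Also open, going by these compounds, is how this place would read with a carboxylic acid, a methyl ester or an amine, and whether the same swap would give a similar step on another core.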